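Trading a chlorophenyl ring for a methyl group

A few compounds are considered here, and "the series" means these few. Any claim that something is new, unique, unknown or untested is made for them only; others in the source may bear on it.

Compound 2, `COc1nc2ccccc2cc1/C=C/c1noc(-c2cccc(Cl)c2)n1`, is one of two compounds tested in an ADME assay on HepG2 cells (Homo sapiens) for cytotoxicity, read by sulforhodamine B assay, with a stated time of 48 h; on this read-out lower numbers stand for higher toxicity in this test and higher numbers for lower toxicity in this test. In this assay compound 2 reaches only the limit > 220000 nM, not a number. Compound 1, `COc1nc2ccccc2cc1/C=C/c1noc(-c2ccccc2Br)n1`, likewise reaches only a limit in this assay, > 195000 nM. The step that the two limits leave unreadable from compound 1 to compound 2 therefore cannot be read, since both the limit of > 195000 nM in this assay, at which 1 of the 2 values shown sits, and the limit of > 220000 nM in this assay, at which 1 of the 2 values shown sits, are limits. Compound 3, `COc1nc2ccccc2cc1/C=C/c1noc(C)n1`, differs from compound 2 by methyl in place of 3-chlorophenyl on an aromatic carbon. For the measured compounds named here, no measured step bears on this change, so no direction beyond the scatter is expected. Compound 3 is expected to give 220000 nM, between 100000 nM and 500000 nM, most likely again as a limit. The expected step of a number no higher from compound 2 to compound 3 (the limit leaves the size open) is accordingly small.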

Compound 3, half-maximal cytotoxic concentration: > 300000 nM
Compound 3: a limit, no number; the forecaster's own chance of this, stated with the estimate: 85%; at least 1.3-fold (0.13 log units) between middle value and limit.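

Compound 3 also gives only a limit in this assay, so its steps from compound 1 and compound 2 cannot be read. The compounds shown leave open whether methyl, 3-chlorophenyl and 2-bromophenyl differ at all in this assay.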